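Fluoro in place of hydrogen on compound 1

The source may hold more compounds than are shown below. What is called first, only, known or untested is meant among the compounds shown, and "the series" means these compounds.

- compound 1 `COc1ccc(C[S+]([O-])CC=CSSCc2ccccc2)cc1`: 3100 nM
- compound 2 `C=CCSS/C=C\C[S+]([O-])CCCN1C(=O)c2ccccc2C1=O`: 33000 nM

In a functional assay on WHCO1 cells (Homo sapiens) for antiproliferative activity, read by MTT assay, with a stated time of 48 h (a lower number here means a stronger inhibitor, a higher number a weaker inhibitor), compound 1 gives 3100 nM, the lower of the two numbers, and compound 2 gives 33000 nM, a gap beyond the usual scatter. These two compounds differ in more than one place, so their gap offers no guide to a single substitution. The next compound, compound 3 `COc1ccc(C[S+]([O-])CC=CSSCc2ccc(F)cc2)cc1`, keeps the core of compound 1 and turns benzyl to 4-fluorobenzyl, with fluoro in place of hydrogen on an aromatic carbon. Among the measured compounds shown here, no measured pair shows this change. In this assay the expectation is therefore a small step in no firm direction, most likely none beyond the scatter. The estimated step is a 1.0-fold lower number from compound 1 to compound 3 (0.01 log units; within the scatter). For compound 3 the expected value is 3000 nM, with an estimated range from 1200 nM to 7500 nM.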

Compound 3, half-maximal inhibitory concentration: 16000 nM
Estimate against measurement, compound 3: 5.3-fold (0.73 log units) below; the whole stated range lies below it.
By their numbers in this assay, from the lowest: compound 1; then compound 3; then compound 2.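

In this assay, among the compounds shown here, turning benzyl to 4-fluorobenzyl on the core of compound 1 gives a 5.2-fold higher number from compound 1 to compound 3 (0.71 log units; beyond the scatter), the first step that can be tied to a single place. This position, on an aromatic carbon para to a large group, therefore does not tolerate even a single fluorine without a loss of activity, something the gap between compound 1 and compound 2 could not show, as those two differ in more than one place. Nothing measured here bears on the origin of this step.

Going by these compounds, with one substituent at this position, it remains open whether the loss is specific to fluoro or would also follow from a chloro group or an amine in the same place. On these data alone, whether the same change would give a step of similar size on another core also remains open.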